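Losing the 2-bromoethenyl group: notes on Vero tolerance

A few compounds are considered here, and "the series" means these few. Any claim that something is new, unique, unknown or untested is made for them only; others in the source may bear on it.

compound 1 (`Nc1nc(O)c2ncn(C[C@]3(CO)C[C@H]3CO)c2n1`) gives 240 ug/mL
compound 2 (`O=c1[nH]c(=O)n(CC2(CO)CC2CO)cc1/C=C/Br`) gives > 500 ug/mL
compound 3 (`O=c1[nH]c(=O)n(CC(CO)C2CC2O)cc1/C=C/Br`) gives > 500 ug/mL

In a functional assay on Vero cells (Chlorocebus sabaeus) for cytotoxicity (a higher number here means that more compound is tolerated, a lower number that less compound is tolerated), compound 2 gives > 500 ug/mL, which is a limit of the assay and not a number. That places compound 2 at the limit of > 500 ug/mL in this assay, at which 2 of the 3 values shown sit. Compound 3 gives > 500 ug/mL, which is also a limit. For the measured compounds named here, compound 1 gives 240 ug/mL, the only actual number so far.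

The next compound to be tested is compound 4 (`O=c1ccn(CC2(CO)CC2CO)c(=O)[nH]1`). Its difference from compound 2 is hydrogen in place of 2-bromoethenyl on an aromatic carbon. Hydrogen takes the place of 2-bromoethenyl on an aromatic carbon, and the rest of the structure stays the same.

Going by the values given here, no measured pair shows this change, so the expectation is only a cautious one. The expected a number no higher from compound 2 to compound 4 (the limit leaves the size open) stays within the usual scatter, with no clear direction. This expectation rests on compound 2, whose > 500 ug/mL is a limit.

For compound 4 the estimate is 500 ug/mL, with an expected range from 200 ug/mL to 1000 ug/mL.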

Compound 4, half-maximal cytotoxic concentration: > 500 ug/mL
Compound 4: only a limit was reported (the forecaster's own chance of this, stated with the estimate: 75%); the middle value sits exactly at the limit.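

In this assay compound 2 and compound 4 both give a limit and not a number, so no step can be read between them. The compounds shown leave open whether hydrogen in place of 2-bromoethenyl on an aromatic carbon changes tolerance at all.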